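The compounds below may be only part of what the source reports. "The series", "measured", "known", "first", "only" and "open" are said of these compounds alone.

Working notes on the series. Compound 1 `COC(=O)c1cccn1-c1ccc(Nc2ncc(Cl)c(Nc3ccccc3NS(C)(=O)=O)n2)c(OC)c1` carries a methyl ester on the shared core; in a functional assay on KARPAS-299 cells (Homo sapiens) for antiproliferative activity, read by MTT assay, with a stated time of 4 h (a higher number here means a weaker inhibitor, a lower number a stronger inhibitor), compound 1 gives 790 nM. Compound 2 `COc1cc(-n2cccc2C(=O)O)ccc1Nc1ncc(Cl)c(Nc2ccccc2NS(C)(=O)=O)n1` carries the free acid, and in this assay compound 2 gives 90 nM. Compound 3 `COc1cc(-n2cccc2C(=O)N2CCCC2)ccc1Nc1ncc(Cl)c(Nc2ccccc2NS(C)(=O)=O)n1` carries the pyrrolidine amide; in this assay compound 3 gives 870 nM, the highest of the three numbers, though the nearest of them lies within the scatter: a 1.1-fold higher number from compound 1 to compound 3 (0.04 log units; within the scatter). The acid stands apart from both: an 8.8-fold lower number from compound 1 to compound 2 (0.94 log units; beyond the scatter) and a 9.7-fold higher number from compound 2 to compound 3 (0.99 log units; beyond the scatter).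

Compound 4 `COc1cc(-n2cccc2C(=O)N(C)C)ccc1Nc1ncc(Cl)c(Nc2ccccc2NS(C)(=O)=O)n1` differs from compound 3 by dimethylamino in place of pyrrolidin-1-yl on a carbonyl carbon. Among the measured compounds shown here, no measured step exchanges one amide for another. The step that bears most on it is a 1.1-fold higher number from compound 1 to compound 3 (0.04 log units; within the scatter), where ester and pyrrolidine amide sit within the scatter of each other; the step of a 9.7-fold higher number from compound 2 to compound 3 (0.99 log units; beyond the scatter) involves the acid and does not carry over. A step within the scatter is therefore expected, a 1.1-fold lower number from compound 3 to compound 4 (0.04 log units; within the scatter). Compound 4 is estimated at 800 nM in this assay, with a range of 300 nM to 2500 nM.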

Compound 4, half-maximal inhibitory concentration: 780 nM
The estimate for compound 4 lay 1.0-fold (0.01 log units) above the measured number; the measured number falls inside the stated range.
By their numbers in this assay, from the lowest: compound 2; then compounds 4, 1 and 3 (each within the scatter of the next).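

Replacing pyrrolidin-1-yl with dimethylamino on this carbonyl carbon removes the ring and two heavy atoms, yet the number in this assay stays within the scatter (a 1.1-fold lower number from compound 3 to compound 4 (0.05 log units; within the scatter)). Compound 4 also lies within the scatter of the methyl ester (a 1.0-fold lower number from compound 1 to compound 4 (0.01 log units; within the scatter)) and beyond it from the free acid (an 8.7-fold higher number from compound 2 to compound 4 (0.94 log units; beyond the scatter)), so the two tertiary amides and the ester form one group of values, with only compound 2 apart from them. Nothing available explains why the acid separates from the other three compounds.

Still open, from the compounds shown here alone, is whether an amide with a hydrogen on its nitrogen, such as the primary amide or the N-methyl amide, would fall with this group or with compound 2. A morpholine amide, or an amide carrying a longer chain that ends in a carboxylic acid or an amine, is equally unresolved.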